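The source may hold more compounds than are shown below. What is called first, only, known or untested is meant among the compounds shown, and "the series" means these compounds.

Compound 1 `CN1CCN(c2ccc(NC(=N)c3cc4cn[nH]c4cn3)cc2)CC1` and compound 3 `COc1ccc(Cn2ncc3cc(C(=N)Nc4ccccc4)ncc32)cc1` share the core that also carries compound 2 `N=C(Nc1ccccc1)c1cc2cn[nH]c2cn1` and compound 4 `N=C(Nc1cccc(C(F)(F)F)c1)c1cc2cn[nH]c2cn1`, differing from one another in the groups hung on the amidine nitrogen and on the pyrazole nitrogen. In a functional assay on HT-1080 cells (Homo sapiens) for cytotoxicity, read by MTT assay, with a stated time of 72 h (on this read-out lower numbers stand for stronger inhibition and higher numbers for weaker inhibition), compound 1 gives 31300 nM. In this assay compound 3 gives 25700 nM. These two numbers lie within the usual scatter of each other, so they point to the same weak range rather than to any ordering.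

Compound 2 stands without a number here: in this assay compound 2 gives "not determined" (no result reported), so nothing can be said about where it sits relative to compound 1 or compound 3. The step from compound 2 to compound 4 is therefore an unanchored one. The change is trifluoromethyl in place of hydrogen on an aromatic carbon, meta to a large group.

Among the measured compounds shown here, with no measured pair to compare, the size and direction of this step cannot be read from the data. For the measured compounds named here, the only guide is the weak range shared by compound 1 and compound 3. On that basis compound 4 is expected to fall near 20000 nM, with a plausible spread from 5000 nM to 80000 nM, and a real chance that only a limit is reported.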

Compound 4, half-maximal inhibitory concentration: 36500 nM
Compound 4: the middle estimate sits 1.8-fold (0.26 log units) below what was measured; the measured number falls inside the stated range.
By their numbers in this assay, from the lowest: compounds 3, 1 and 4 (each within the scatter of the next).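

Among the compounds shown here, with no single number for compound 2 in this assay, no step from compound 2 to compound 4 can be read. The compounds shown leave open whether trifluoromethyl in place of hydrogen on the aromatic carbon shifts the value in this assay at all. No evidence at hand bears on this result.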